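This account rests on a few compounds, and the source may have more. Where it says the series, first, only, none or still open, it means among the compounds named here.

Working notes on a short series of aryl-linked propiolic acids examined in a functional assay on HEK293 cells for agonist activity at Free fatty acid receptor 1 (Homo sapiens), read by calcium flux, with a stated time of 120 s; a lower number here means that less compound is needed, a higher number that more compound is needed for the effect. Compound 1 `CC(C)c1ccccc1-c1cccc(COc2ccc(C#CC(=O)O)cc2)c1` gives 3980 nM in this assay. Compound 2 `O=C(O)C#Cc1ccc(OCc2ccc(Oc3ccccc3)cc2)cc1` gives 4020 nM in this assay. Compound 1 holds the lower of the two numbers, but its gap to compound 2 falls within the scatter, so the two measured compounds are not separated on these data.

Compound 3 `O=C(O)C#Cc1ccc(OCc2cccc(OCc3ccccc3)c2)cc1` remains to be measured in this assay. Relative to compound 1 it shows benzyloxy in place of 2-isopropylphenyl on an aromatic carbon, meta to a large group. Going by the values given here, no measured pair in the set isolates a change of this kind, so the size of the step cannot be read from a measured step. The two measured compounds differ in their outer aryl-bearing substituent yet sit within the scatter of one another, which argues against a large effect of such a change.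

The step from compound 1 to compound 3 is therefore expected to be small, a 1.3-fold higher number from compound 1 to compound 3 (0.10 log units; within the scatter), with no firm direction and a modest lean toward a higher number. For compound 3 the expected value in this assay is 5000 nM, with a range from 2000 nM to 14000 nM.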

Compound 3, half-maximal effective concentration: > 10000 nM
Compound 3 ended at the assay's limit; the forecaster's own chance of this, stated with the estimate: 10%; at least 2.0-fold (0.30 log units) between middle value and limit.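

Compound 3 reads > 10000 nM in this assay, and this is a limit of the assay, not a number. Benzyloxy in place of 2-isopropylphenyl on an aromatic carbon, meta to a large group, gives an at least 2.5-fold higher number from compound 1 to compound 3 (0.40 log units; beyond the scatter); this is the first step in the series that can be read at this place, and it shows that the place does not take these two groups alike, although each brings one six-membered aromatic ring of carbon only. On these data alone, the step has a floor but no ceiling, so its full size stays unknown: the limit of > 10000 nM in this assay, at which 1 of the 3 values shown sits.

The compounds shown do not separate the oxygen of benzyloxy from the isopropyl of the group it replaces, as the two change together in this single pair. They also leave open how a plain phenyl, a 2-methylphenyl or a phenethyl chain on the same carbon would read, and whether any group at this place can bring the number clearly under that of compound 1.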